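Methoxy in place of ethyl: compound 2 to compound 3

The source may report more compounds than this note shows. Statements on the series, on what has been measured and on what is new or still open speak of the compounds shown alone.

For the measured compounds named here, compound 2 `CCc1cccc(NC(=O)CSc2nc(Nc3ccccc3)c3ccccc3n2)c1` has the lower of the two numbers so far in a functional assay on MDA-MB-231 cells (Homo sapiens) for inhibition, read by MTT assay, with a stated time of 72 h; a higher number here means a weaker inhibitor, a lower number a stronger inhibitor: compound 2 gives 12400 nM. Compound 1 `O=C(CSc1nc(Nc2ccccc2)c2ccccc2n1)Nc1cccc(Cl)c1` in this assay gives 16500 nM; the step of a 1.3-fold lower number from compound 1 to compound 2 (0.12 log units; within the scatter) is within the scatter, so the two compounds cannot be separated on this read-out.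

Compound 3 `COc1cccc(NC(=O)CSc2nc(Nc3ccccc3)c3ccccc3n2)c1` differs from compound 2 by methoxy in place of ethyl on an aromatic carbon. Going by the values given here, the one measured step that touches the same position, a 1.3-fold lower number from compound 1 to compound 2 (0.12 log units; within the scatter), exchanged chloro for ethyl and stayed within the scatter. Among the compounds with values here, no measured compound carries methoxy, so the direction of the change from ethyl to methoxy cannot be read from the series itself. Within the data shown here, because the single available step at this position, a 1.3-fold lower number from compound 1 to compound 2 (0.12 log units; within the scatter), gave no movement beyond the scatter, the expected step of a 1.0-fold higher number from compound 2 to compound 3 (0.02 log units; within the scatter) is set at none beyond the scatter, with a range wide enough to admit a modest move either way. For compound 3 the half-maximal inhibitory concentration in this assay is estimated at 13000 nM, with a range from 6000 nM to 28000 nM.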

Compound 3, half-maximal inhibitory concentration: 21700 nM
Compound 3: middle estimate off by 1.7-fold (0.22 log units), on the low side, within the range that was stated.
By their numbers in this assay, from the lowest: compounds 2, 1 and 3 (each within the scatter of the next).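

In this assay, the exchange of ethyl for methoxy gives a 1.8-fold higher number from compound 2 to compound 3 (0.24 log units; within the scatter), and the exchange of chloro for methoxy gives a 1.3-fold higher number from compound 1 to compound 3 (0.12 log units; within the scatter). Together with the earlier chloro-to-ethyl step, this closes the comparison among all three groups: on this aromatic carbon, meta to a large group, chloro, ethyl and methoxy cannot be separated on this read-out, and this holds even though methoxy brings a hydrogen-bond acceptor that neither of the other two groups has in the counts for this position's ethyl-to-methoxy change. No measurement on these compounds bears on the reason for these values.

Still open is whether a group of another kind at this position, such as an amine, a carboxylic acid or a chain longer than ethyl, would give a step beyond the scatter, since the three groups shown span only a narrow set of small substituents. Also open, as far as these compounds go, is whether the same insensitivity would hold on another carbon of this ring or with any change to the shared core, which stays the same in all three compounds.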